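Chloro for fluoro on the aromatic ring: working notes

The source may report more compounds than this note shows. Statements on the series, on what has been measured and on what is new or still open speak of the compounds shown alone.

Measured in a functional assay on PC-3 cells (Homo sapiens) for cytotoxicity, read by sulforhodamine B assay, with a stated time of 48 h; a lower number here means a stronger inhibitor, a higher number a weaker inhibitor:
- compound 1 `C[C@H]1CC[C@@H]2[C@@H](OC(=O)[C@]23CC(c2ccc(O)cc2)=NO3)[C@]2(C)C(=O)C=C[C@@]12O`: 20000 nM
- compound 2 `C[C@H]1CC[C@@H]2[C@@H](OC(=O)[C@]23CC(c2ccccc2F)=NO3)[C@]2(C)C(=O)C=C[C@@]12O`: 8200 nM

Compound 2 has the lower of the two numbers, at 8200 nM. Compound 3 `C[C@H]1CC[C@@H]2[C@@H](OC(=O)[C@]23CC(c2ccccc2Cl)=NO3)[C@]2(C)C(=O)C=C[C@@]12O` carries chloro in place of fluoro on an aromatic carbon, ortho to a large group: chloro in place of fluoro on an aromatic carbon. For the measured compounds named here, the one measured step, a 2.4-fold lower number from compound 1 to compound 2 (0.39 log units; beyond the scatter), is modest and replaces 4-hydroxyphenyl with 2-fluorophenyl. Going by the values given here, no measured step exchanges one halogen for another, so no step beyond the scatter is expected in this assay. The estimated change is a 1.2-fold lower number from compound 2 to compound 3 (0.07 log units; within the scatter). The expected value for compound 3 is 7000 nM, with an estimated range from 2500 nM to 20000 nM.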

Compound 3, half-maximal inhibitory concentration: 12000 nM
Compound 3: the middle estimate sits 1.7-fold (0.23 log units) below what was measured, and the stated range covers the measured number.
By their numbers in this assay, from the lowest: compounds 2, 3 and 1 (each within the scatter of the next, the first and the last beyond it).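

In this assay, exchanging the halogen on this aromatic carbon, ortho to a large group, gives a 1.5-fold higher number from compound 2 to compound 3 (0.17 log units; within the scatter) and leaves fluoro and chloro unresolved here. The step of a 1.7-fold lower number from compound 1 to compound 3 (0.22 log units; within the scatter) also leaves 2-chlorophenyl unresolved from 4-hydroxyphenyl, whereas 2-fluorophenyl was resolved from it by a 2.4-fold lower number from compound 1 to compound 2 (0.39 log units; beyond the scatter), so the two halogens do not separate from each other, yet only fluoro separates from the 4-hydroxyphenyl compound. Nothing available explains these numbers. Going by these compounds, whether an amine or a carboxylic acid at this place would move the number beyond the scatter remains open.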